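Swapping a sulfonyl for a methoxybenzyl on a ring amine

A few compounds are considered here, and "the series" means these few. Any claim that something is new, unique, unknown or untested is made for them only; others in the source may bear on it.

Measured compounds:
compound 1 `CN(C)CCN1CCN(c2nc(-c3ccccn3)nc3c2CN(S(=O)(=O)c2ccccc2)CC3)CC1` — 100000 nM
compound 2 `COc1ccc(Cl)cc1Cc1cc(-c2sc(NC(=O)C(C)(C)C)nc2C)nn1C(=O)NCCO` — 3020 nM

In an assay on cells with Cystic fibrosis transmembrane conductance regulator variant F508del (Homo sapiens) as the target, read by fluorescence, with stated times of 24 h and 30 min (on this read-out higher numbers stand for an effect only at larger amounts of compound and lower numbers for an effect already at smaller amounts), compound 1 gives 100000 nM, the higher of the two numbers recorded. Compound 2, built on a different core, gives 3020 nM in this assay, a gap that lies beyond the usual scatter. Compound 3 `COc1ccc(CN2CCc3nc(-c4ccccn4)nc(N4CCN(CCN(C)C)CC4)c3C2)cc1` keeps the core of compound 1 and differs from it in one place: 4-methoxybenzyl in place of phenylsulfonyl on an amine nitrogen in a ring. Among the compounds with values here, no measured pair shows the effect of this exchange, so the expectation rests on the position of compound 1 alone. Because compound 1 sits at 100000 nM, there is more room for the number to fall than to rise, and a step downward of moderate size is expected, a 3.3-fold lower number from compound 1 to compound 3 (0.52 log units; beyond the scatter), though a result within the scatter cannot be ruled out. Compound 3 is therefore estimated at 30000 nM in this assay, with a range from 5000 nM to 100000 nM.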

Compound 3, half-maximal effective concentration: 100000 nM
For compound 3 the middle estimate is 3.3-fold (0.52 log units) below the measured one; low and high end bracket the measured number.
By their numbers in this assay, from the lowest: compound 2; then compounds 1 and 3 (each within the scatter of the next).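

In this assay, within the data shown here, 4-methoxybenzyl in place of phenylsulfonyl on the amine nitrogen in a ring gives no change at the digits printed from compound 1 to compound 3 (within the scatter), the first reading of any exchange at this position. On the core of compound 1, this nitrogen therefore takes either group without a shift in the number, even though the sulfur and the two double bonds outside aromatic rings leave and the count of hydrogen-bond acceptors differs. Nothing available explains why the two groups read alike.

This single pair leaves open whether the number at this nitrogen can move at all, for instance with a free amine, an acetyl group or a longer chain ending in a carboxylic acid. It also leaves open whether changes elsewhere on the shared core would move it.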